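The compounds below may be only part of what the source reports. "The series", "measured", "known", "first", "only" and "open" are said of these compounds alone.

Three compounds share one core and were tested in a functional assay on SMMC-7721 cells (Homo sapiens) for inhibition, read by MTT assay, with a stated time of 72 h, tested at 1 uM; on this read-out higher numbers stand for a stronger effect at the one concentration tested and lower numbers for a weaker effect. Compound 1 `Clc1ccc(COc2ccccc2/C=C/C(/C=C/c2ccccn2)=N/Oc2ncnc3cc(Cl)ccc23)cc1` gives 94%, the highest of the three. Compound 2 `Cc1cccc2ncnc(O/N=C(/C=C/c3ccc(OCc4ccccc4Cl)cc3)\C=C\c3ccccn3)c12` gives 77%, and compound 3 `Cc1cccc(COc2ccc(/C=C/C(/C=C/c3ccccn3)=N/Oc3ncnc4ccccc34)cc2)c1` gives 69.2%; both gaps from compound 1 are beyond the scatter. Compound 4 `Clc1ccc2c(O/N=C(\C=C\c3ccccn3)/C=C/c3ccccc3OCc3ccccc3Cl)ncnc2c1` differs from compound 1 in a single place: 2-chlorophenyl in place of 4-chlorophenyl on a saturated chain carbon bound to an oxygen on an aromatic ring. For the measured compounds named here, no pair of measured compounds shows this exact change alone, so its effect is open; compound 2, which carries a 2-chlorophenyl group on a different core, sits lower than compound 1, but other differences are mixed in. Moving the chlorine around one ring is expected to change the read-out little, with a step from a number 9 percentage points lower from compound 1 to compound 4 (within the scatter) that may not exceed the scatter. Compound 4 is therefore estimated at 85%, in a range from 65% to 97%.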

Compound 4, a percentage reported as inhibition, at one concentration (the size of the read-out at that concentration, not a potency): 94.8%
For compound 4 the middle estimate is 9.8 percentage points below the measured one; the range from low to high includes it.
By their numbers in this assay, from the lowest: compounds 3 and 2 (each within the scatter of the next); then compounds 1 and 4 (each within the scatter of the next).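

In this assay the swap of 4-chlorophenyl for 2-chlorophenyl on this saturated chain carbon gives a number 0.8 percentage points higher from compound 1 to compound 4 (within the scatter) and so offers the first one-place comparison among these compounds. At this single concentration, the chlorine can sit in either ring position without a readable change in inhibition. Nothing measured here explains why the two compounds read alike. A single concentration cannot show whether their potencies differ. Also open, as far as these compounds go, is how this ring would respond if a methoxy group or an amine took the place of the chlorine.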